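The compounds below may be only part of what the source reports. "The series", "measured", "known", "first", "only" and "open" are said of these compounds alone.

Measured compounds in a functional assay on HT-29 cells (Homo sapiens) for cytotoxicity, read by MTT assay, with a stated time of 24 h; a higher number here means a weaker inhibitor, a lower number a stronger inhibitor:
compound 1 `COc1cc(/C=C2\SC(=O)N(Cc3ccc(C(=O)O)cc3)C2=O)cc(OC)c1OC` gives 32000 nM
compound 2 `O=C(O)c1ccc(CN2C(=O)S/C(=C\c3ccccn3)C2=O)cc1` gives 78000 nM
compound 3 `O=C(O)c1ccc(CN2C(=O)S/C(=C\c3cccs3)C2=O)cc1` gives 88000 nM

Compound 3 holds the highest of the three numbers. Its gap to compound 2 lies within the scatter, so no order between compound 2 and compound 3 can be read from these values. For the measured compounds named here, compound 1 is the only compound whose number stands beyond the scatter from compound 3, and it is the lower one. A single one-place step connects two measured compounds: a 1.1-fold higher number from compound 2 to compound 3 (0.05 log units; within the scatter).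

The next compound is compound 4 `O=C(O)c1ccc(CN2C(=O)S/C(=C\c3ccc(F)cc3)C2=O)cc1`. It differs from compound 3 as follows: 4-fluorophenyl in place of thiophen-2-yl on a double-bonded chain carbon bound to a double-bonded ring carbon.

Going by the values given here, the one measured step bears on this change in that it also swaps one aromatic group for another at the same place, and that swap stayed within the scatter. Compound 1 also carries a six-membered ring of carbon only at this place and shows a lower number than compound 3, but it differs from compound 4 in more than one place, so only its value can be weighed. The expectation is therefore a modest step downward, which may not reach beyond the scatter. The expected step from compound 3 is a 1.5-fold lower number from compound 3 to compound 4 (0.17 log units; within the scatter). For compound 4 the estimated value in this assay is 60000 nM, with an expected range from 25000 nM to 150000 nM.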

Compound 4, half-maximal inhibitory concentration: 32000 nM
Beside the measured number, compound 4's estimate is 1.9-fold (0.27 log units) above it, within the range that was stated.
By their numbers in this assay, from the lowest: compounds 1 and 4 (each within the scatter of the next); then compounds 2 and 3 (each within the scatter of the next).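

In this assay the place on a double-bonded chain carbon bound to a double-bonded ring carbon now shows that the choice of aromatic group can move the number beyond the scatter: the changes are modest, with (a 2.8-fold lower number from compound 3 to compound 4 (0.44 log units; beyond the scatter)) and (a 2.4-fold lower number from compound 2 to compound 4 (0.39 log units; beyond the scatter)), whereas the earlier swap at this place (a 1.1-fold higher number from compound 2 to compound 3 (0.05 log units; within the scatter)) gave no readable order. Among these three one-place neighbours, 4-fluorophenyl, a six-membered aromatic ring of carbon only, stands apart from both thiophen-2-yl and pyridin-2-yl, which remain unresolved from each other. These numbers alone cannot separate the change of ring from the entry of fluorine, and no supporting measurement gives a reason for the step.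

From the compounds shown here alone, whether the same step holds with unsubstituted phenyl or 4-chlorophenyl at this place stays open, so the share of the fluorine in it cannot yet be judged. Also open, going by these compounds, is whether the step survives when the carboxylic acid of the shared core gives way to a primary amide.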